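From a hexyl urea to a methoxyphenyl amine

A few compounds are considered here, and "the series" means these few. Any claim that something is new, unique, unknown or untested is made for them only; others in the source may bear on it.

In a functional assay on WI-38 VA13 cells (Homo sapiens) for cytotoxicity (a lower number here means that less compound is needed, a higher number that more compound is needed for the effect), compound 1 `O=C(Nc1ccc2nc(NC(=O)C3CC3)sc2c1)c1c(Cl)cccc1Cl` gives 0.013 ug/mL. Compound 2 `O=C(O)CCC(=O)Nc1nc2ccc(NC(=O)c3c(Cl)cccc3Cl)cc2s1` sits at the limit of > 6.6 ug/mL in this assay, at which 1 of the 3 values shown sits, so its value > 6.6 ug/mL is a limit of this assay and not a number. For the measured compounds named here, compound 3 `CCCCCCNC(=O)Nc1nc2ccc(NC(=O)c3c(Cl)cccc3Cl)cc2s1` gives 0.29 ug/mL, the highest of the two numbers known in this assay; the nearest number belongs to compound 1, and the step of a 22-fold higher number from compound 1 to compound 3 (1.35 log units; beyond the scatter) shows how far apart they lie. Compound 4 `COc1ccccc1Nc1nc2ccc(NC(=O)c3c(Cl)cccc3Cl)cc2s1` has not yet been measured. It differs from compound 3 in one place: 2-methoxyphenyl in place of hexylcarbamoyl on a nitrogen on an aromatic ring. Of the measured steps, the three that exchange the group on the carbonyl carbon bear on this change: an at least 500-fold higher number from compound 1 to compound 2 (2.70 log units; beyond the scatter), a 22-fold higher number from compound 1 to compound 3 (1.35 log units; beyond the scatter) and an at least 22-fold lower number from compound 2 to compound 3 (1.35 log units; beyond the scatter), so the group attached to this nitrogen moves the number strongly in both directions. None of them, however, puts an aromatic ring directly on that nitrogen and removes the carbonyl altogether, so the direction of the new step is open. Given the large swings seen, the step of a 1.4-fold higher number from compound 3 to compound 4 (0.14 log units; within the scatter) is expected to be modest, with a wide band of uncertainty in either direction. Compound 4 is therefore estimated at 0.4 ug/mL, in a range from 0.05 ug/mL to 3 ug/mL.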

Compound 4, half-maximal effective concentration: > 7.2 ug/mL
Compound 4: no number, only a limit; the forecaster's own chance of this, stated with the estimate: 15%; at least 18-fold (1.25 log units) between middle value and limit.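

For the compounds shown here, putting 2-methoxyphenyl on the nitrogen on an aromatic ring, which also removes the carbonyl held there by the earlier compounds, gives the step of an at least 24-fold higher number from compound 3 to compound 4 (1.39 log units; beyond the scatter), and measured against the cyclopropylcarbonyl group the change gives the step of an at least 550-fold higher number from compound 1 to compound 4 (2.74 log units; beyond the scatter). In this assay, going by these compounds alone, the earlier compounds showed only exchanges of the group on the carbonyl carbon, while this result shows that a group with an aromatic ring and no carbonyl can also move the read-out beyond the scatter, here towards more compound being needed. Compound 4 stands at a limit of the assay and not at a number, and compound 2 does too, so the step between these two cannot be read: the limit of > 7.2 ug/mL in this assay, at which 1 of the 4 values shown sits.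

The compounds shown leave open whether this shift follows from the lost carbonyl or from the 2-methoxyphenyl group itself, a question that a hexyl chain set directly on the nitrogen, or a 2-methoxybenzoyl group on it, would help to separate. From the compounds shown here alone, what number compound 4 would give in this assay also remains unknown.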